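From 4-methylphenyl to 3-bromophenyl on the amide nitrogen

The compounds below may be only part of what the source reports. "The series", "measured", "known", "first", "only" and "open" are said of these compounds alone.

Of the compounds shown here, three with a shared core have been measured in a functional assay on OVCAR-5 cells (Homo sapiens) for inhibition, read by CCK-8 assay, with a stated time of 72 h, tested at 10 uM; a higher number here means more inhibition of growth at the concentration tested, a lower number less inhibition of growth. In this test, compound 1 (`CN(C)C(=O)c1cc2cnc(Nc3ccc(NC(=O)C4(C(=O)Nc5ccc(Cl)cc5)CC4)cc3)nc2n1C1CCCC1`) gives 85.3%, compound 2 (`CN(C)C(=O)c1cc2cnc(Nc3ccc(NC(=O)C4(C(=O)Nc5cccc(O)c5)CC4)cc3)nc2n1C1CCCC1`) gives 86% and compound 3 (`Cc1ccc(NC(=O)C2(C(=O)Nc3ccc(Nc4ncc5cc(C(=O)N(C)C)n(C6CCCC6)c5n4)cc3)CC2)cc1`) gives 80.6%. Compound 3 therefore stands within the scatter of the other two, as the data show a number 4.7 percentage points lower from compound 1 to compound 3 (within the scatter) and a number 5.4 percentage points lower from compound 2 to compound 3 (within the scatter).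

Compound 4 (`CN(C)C(=O)c1cc2cnc(Nc3ccc(NC(=O)C4(C(=O)Nc5cccc(Br)c5)CC4)cc3)nc2n1C1CCCC1`) has not yet been measured. It carries 3-bromophenyl in place of 4-methylphenyl on an amide-type nitrogen. The two steps above also change the group on that nitrogen, as does a number 0.7 percentage points higher from compound 1 to compound 2 (within the scatter). Among the compounds with values here, all three stay within the scatter, although no measured compound carries bromine, so this evidence is indirect.

No step beyond the scatter is therefore expected in this assay, and the estimated change is a number 3.4 percentage points higher from compound 3 to compound 4 (within the scatter). The expected value for compound 4 is 84%, with an estimated range of 74% to 92%.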

Compound 4, percent growth inhibition at one concentration: 89.6%
Estimate against measurement, compound 4: 5.6 percentage points below; the measured number falls inside the stated range.
By their numbers in this assay, from the lowest: compounds 3, 1, 2 and 4 (each within the scatter of the next).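

In this assay the 3-bromophenyl group on the amide-type nitrogen stays within the scatter of all three earlier groups: the data give a number 9 percentage points higher from compound 3 to compound 4 (within the scatter) and a number 4.3 percentage points higher from compound 1 to compound 4 (within the scatter) and also a number 3.6 percentage points higher from compound 2 to compound 4 (within the scatter) for the exchange of hydroxy for bromo on an aromatic carbon. Bromine, carried by none of the earlier compounds, thus brings no step beyond the scatter at this position, and the hydroxy of compound 2 is not needed to stay within it. Nothing available explains these small steps or says what lies behind them.

As far as these compounds go, whether an amine or a carboxylic acid on this phenyl ring, or a longer chain in place of the ring, would also stay within the scatter remains open. So does whether these compounds would separate at lower concentrations.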